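Swapping the amide aryl group: an estimate for compound 4

A few compounds are considered here, and "the series" means these few. Any claim that something is new, unique, unknown or untested is made for them only; others in the source may bear on it.

In an assay on CHO cells for agonist activity at G protein-coupled receptor GPR35 (Rattus norvegicus), read by a beta-galactosidase reporter and beta-arrestin recruitment, with a stated time of 90 min (a higher number here means that more compound is needed for the effect, a lower number that less compound is needed), the three measured compounds gave these numbers:

Compound 1 `COc1ccc(C(=O)Nc2cc(Br)cc3c(=O)cc(C(=O)O)oc23)c(Cl)c1`: 4170 nM
Compound 2 `O=C(Nc1cc(F)cc2c(=O)cc(C(=O)O)oc12)c1ccc(Cl)c(Cl)c1`: 2650 nM
Compound 3 `O=C(Nc1cc(Br)cc2c(=O)cc(C(=O)O)oc12)c1ccc(Cl)c(Cl)c1`: 3250 nM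

Compound 3 has a number that sits between those of compound 1 and compound 2, but neither gap is meaningful: the step of a 1.3-fold lower number from compound 1 to compound 3 (0.11 log units; within the scatter) and the step of a 1.2-fold higher number from compound 2 to compound 3 (0.09 log units; within the scatter) are both within the scatter, so the three compounds cannot be told apart in this assay.

Compound 4 `N#Cc1ccc(C(=O)Nc2cc(Br)cc3c(=O)cc(C(=O)O)oc23)cc1` is made from compound 3 by one change: 4-cyanophenyl in place of 3,4-dichlorophenyl on a carbonyl carbon. Within the data shown here, of the measured steps, only the one from compound 1 to compound 3 touches the same aryl group on the carbonyl carbon, and that swap left the number essentially unchanged. The step from compound 2 to compound 3 alters the halogen on the core instead and says nothing about this position. Among the measured compounds shown here, no measured compound carries a nitrile group, so its effect is simply unknown.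

Given that the one aryl swap seen so far was within the scatter, compound 4 is expected to move by a 1.2-fold higher number from compound 3 to compound 4 (0.09 log units; within the scatter), a shift that may well be nothing beyond the scatter. The estimate for compound 4 in this assay is 4000 nM, with a range from 1500 nM to 12000 nM.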

Compound 4, half-maximal effective concentration: 2260 nM
Compound 4: the middle estimate sits 1.8-fold (0.25 log units) above what was measured; low and high end bracket the measured number.
By their numbers in this assay, from the lowest: compounds 4, 2, 3 and 1 (each within the scatter of the next).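

Across the aryl groups on this carbonyl carbon, the number in this assay has still not moved beyond the scatter. Replacing 3,4-dichlorophenyl with 4-cyanophenyl gives a 1.4-fold lower number from compound 3 to compound 4 (0.16 log units; within the scatter), and replacing 2-chloro-4-methoxyphenyl with the same group gives a 1.8-fold lower number from compound 1 to compound 4 (0.27 log units; within the scatter). Until now, the aryl groups compared here all carried chlorine, whereas compound 4 shows that a ring with no chlorine and a nitrile instead also stays within the scatter of both compared compounds, though nothing available here explains this result.

Still open, from the compounds shown here alone, is whether a larger change at this carbonyl carbon would produce a step beyond the scatter, such as an aryl ring carrying an amine or a hydroxyl group, or a saturated cyclohexyl group in place of the aromatic ring. Among these compounds, it is also unknown whether 4-cyanophenyl would give a similar number with fluoro rather than bromo on the shared core, as the step between those two halogens has so far been seen only with 3,4-dichlorophenyl.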